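The compounds below may be only part of what the source reports. "The series", "measured", "known", "first", "only" and "open" are said of these compounds alone.

Compound 1 `COc1cccc(/C(=C\c2cn(C(C)=O)c3ccc(OCc4ccccc4)cc23)C(=O)O)c1`: > 100000 nM
Compound 2 `COc1ccc(/C(=C\c2c[nH]c3ccc(OCc4ccccc4)cc23)C(=O)O)cc1`: 58400 nM

In a functional assay on M14 cells (Homo sapiens) for cytotoxicity, read by MTT assay, with a stated time of 72 h (a higher number here means a weaker inhibitor, a lower number a stronger inhibitor), compound 1 gives only a limit of the assay, > 100000 nM; it sits at the limit of > 100000 nM in this assay, at which 1 of the 2 values shown sits. In this assay compound 2 gives 58400 nM. Compound 3 `COc1cc(/C(=C\c2cn(C(C)=O)c3ccc(OCc4ccccc4)cc23)C(=O)O)cc(OC)c1OC` carries 3,4,5-trimethoxyphenyl in place of 3-methoxyphenyl on a double-bonded chain carbon bound to a carbonyl carbon and a double-bonded chain carbon. For the measured compounds named here, no measured pair differs in this one place, so no step is known to guide the expectation, and compound 1 itself offers no number, only a limit. The value of compound 3 is therefore estimated with wide uncertainty as 90000 nM, between 20000 nM and 400000 nM. This estimate implies a step of an at least 1.1-fold lower number from compound 1 to compound 3 (0.04 log units; that floor lies within the scatter), likely within the scatter or ending again at a limit.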

Compound 3, half-maximal inhibitory concentration: 57100 nM
For compound 3 the middle estimate is 1.6-fold (0.20 log units) above the measured one; measured number inside the range.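

Putting 3,4,5-trimethoxyphenyl in place of 3-methoxyphenyl on this double-bonded chain carbon gives, in this assay, an at least 1.7-fold lower number from compound 1 to compound 3 (0.24 log units; that floor lies within the scatter). Compound 3 gives a true number, whereas compound 1 gives only a limit. Only a floor for the step is therefore known, and the real size of the change cannot be read, because the comparison starts from a limit: the limit of > 100000 nM in this assay, at which 1 of the 3 values shown sits.

Going by these compounds, it remains open how a phenyl ring carrying an amine or a chlorine would read at this place. On these data alone, it also remains open whether any group here could bring the number far lower.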